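Aminothiophene ketones: aryl swap to dimethylisoxazole

The source may hold more compounds than are shown below. What is called first, only, known or untested is meant among the compounds shown, and "the series" means these compounds.

Measured so far:
compound 1 `CC(C)(C)Cc1c(-c2cc(F)ccc2F)sc(N)c1C(=O)c1ccc(Cl)cc1` gives 1% in this assay
compound 2 `COc1ccc(-c2sc(N)c(C(=O)c3ccc(Cl)c(Cl)c3)c2CC(C)(C)C)cc1` gives 1% in this assay

Both were read in an assay on CHO cells for displacement of a labelled ligand from adenosine receptor A3 (Homo sapiens), read by scintillation counting, tested at 10 uM; on this read-out higher numbers stand for more inhibition at the one concentration tested (going by the name of the read-out) and lower numbers for less inhibition. Compound 1 stands level with compound 2 at the digits shown; the two are within the usual scatter of each other, and no ordering can be drawn from them.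

Compound 3 `Cc1noc(C)c1-c1sc(N)c(C(=O)c2ccc(Cl)cc2)c1CC(C)(C)C` differs from compound 1 by 3,5-dimethyl-1,2-oxazol-4-yl in place of 2,5-difluorophenyl on an aromatic carbon. For the measured compounds named here, no measured pair covers this change, so nothing points either way. Because compound 1 gives 1% and compound 2 gives 1%, both low on this read-out, the step of a number 3 percentage points higher from compound 1 to compound 3 (within the scatter) is expected to stay within the scatter. Compound 3 is therefore estimated at 4%, with a range of 0% to 20%.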

Compound 3, a percentage reported as inhibition, at one concentration (the size of the read-out at that concentration, not a potency): 1%
Compound 3: the middle estimate sits 3 percentage points above what was measured, within the range that was stated.
By their numbers in this assay, from the lowest: compounds 1, 2 and 3 (each within the scatter of the next).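

In this assay, 3,5-dimethyl-1,2-oxazol-4-yl in place of 2,5-difluorophenyl gives no change at the digits printed from compound 1 to compound 3 (within the scatter) and so this position now carries a five-membered aromatic ring with 2 hetero atoms as well as a six-membered carbon ring, with no separation between them. For the compounds shown here, all values remain low, so this step shows only that neither ring lifts the number at the one concentration tested. No evidence bears on this result.

From the compounds shown here alone, whether an amine or a carboxylic acid at this position would lift the number stays open. So does whether a longer chain in place of the neopentyl group would move it.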